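Extending the alkoxy chain on a benzotriazine dioxide series

This account rests on a few compounds, and the source may have more. Where it says the series, first, only, none or still open, it means among the compounds named here.

Measured compounds:
compound 1, `COCNc1n[n+]([O-])c2ccccc2[n+]1[O-]`: 2770 nM
compound 2, `CC(OCNc1n[n+]([O-])c2ccccc2[n+]1[O-])c1ccccc1`: 2810 nM

The account follows a shared core carrying an alkoxymethylamino side chain. In a functional assay on A549 cells (Homo sapiens) for cytotoxicity, read by MTT assay, with a stated time of 72 h (on this read-out higher numbers stand for weaker inhibition and lower numbers for stronger inhibition), compound 1 gives 2770 nM, and in this assay compound 2 gives 2810 nM. Compound 1 has the lower of the two numbers shown, but the gap to compound 2 lies within the usual scatter, so the two cannot be told apart; whatever sits past the oxygen on the saturated carbon, a methyl or a phenylethyl, the number stays where it is.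

Compound 3, `CCCCCCCOCNc1n[n+]([O-])c2ccccc2[n+]1[O-]`, has not been measured in this assay. It differs from compound 1 by hexyl in place of hydrogen on a saturated chain carbon bound to an oxygen on a saturated carbon. For the measured compounds named here, no measured pair maps this exact change, so the expectation rests on the two values above, which show no movement across a far larger change at the same place.

Compound 3 is therefore expected to sit close to compound 1, with a step of a 1.1-fold lower number from compound 1 to compound 3 (0.04 log units; within the scatter) that stays within the scatter or is at most a small shift in either direction. The estimate for compound 3 is 2500 nM, with a range of 1000 nM to 6000 nM.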

Compound 3, half-maximal inhibitory concentration: 3490 nM
Beside the measured number, compound 3's estimate is 1.4-fold (0.14 log units) below it; the range from low to high includes it.
By their numbers in this assay, from the lowest: compounds 1, 2 and 3 (each within the scatter of the next).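

In this assay the change to hexyl in place of hydrogen on a saturated chain carbon bound to an oxygen on a saturated carbon gives a 1.3-fold higher number from compound 1 to compound 3 (0.10 log units; within the scatter) and so leaves the number inside the scatter with a straight chain at this place. The earlier pair held only a methyl and a phenylethyl, so this result adds an unbranched, ring-free chain, read one bond further out as methyl to heptyl, to the groups that do not separate from one another here. Across compound 1 and compound 3, then, the 6 carbon atoms that enter bring no step that can be told from repeated measurement, and nothing measured alongside these compounds offers an explanation for this.

What the compounds shown leave open is whether this flat picture lasts with a chain longer than heptyl, or whether it ends once a chain carries something other than carbon, such as an amine, a hydroxyl or a carboxylic acid. They also leave open whether a ring-bearing chain other than phenylethyl, such as one ending in a pyridine, would stay inside the scatter.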